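The compounds below may be only part of what the source reports. "The series", "measured", "known", "first", "only" and "open" are said of these compounds alone.

Series notes. The shared core of compound 1 `O=C(O)CCc1ccc(NC(=O)c2nnc(COc3ccc(F)cc3)s2)cc1` carries an aryl group on an oxygen on a saturated carbon. In a functional assay on CHO cells for agonist activity at Free fatty acid receptor 1 (Homo sapiens), read by FLIPR and calcium flux, tested at 1 uM (a lower number here means that less compound is needed, a higher number that more compound is needed for the effect), compound 1 gives 5390 nM; compound 2 `Cc1ccc(C)c(OCc2nnc(C(=O)Nc3ccc(CCC(=O)O)cc3)s2)c1` gives 1530 nM; compound 3 `Cc1ccc(OCc2nnc(C(=O)Nc3ccc(CCC(=O)O)cc3)s2)c(C)c1` gives 2540 nM. Compound 3 stands apart from compound 1 by a 2.1-fold lower number from compound 1 to compound 3 (0.33 log units; beyond the scatter), while a 1.7-fold higher number from compound 2 to compound 3 (0.22 log units; within the scatter). Compound 4 `O=C(O)CCc1ccc(NC(=O)c2nnc(COc3cccc(C(F)(F)F)c3)s2)cc1` differs from compound 3 by 3-(trifluoromethyl)phenyl in place of 2,4-dimethylphenyl on an oxygen on a saturated carbon. For the measured compounds named here, the steps that bear on this are a 3.5-fold lower number from compound 1 to compound 2 (0.55 log units; beyond the scatter) and a 2.1-fold lower number from compound 1 to compound 3 (0.33 log units; beyond the scatter), both modest and both obtained on moving away from an aryl bearing fluorine. The incoming aryl again carries fluorine, as in compound 1, so a modest rise in the number is expected for compound 4, a 1.4-fold higher number from compound 3 to compound 4 (0.14 log units; within the scatter). Compound 4 is therefore estimated at 3500 nM, with a range of 1500 nM to 9000 nM.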

Compound 4, half-maximal effective concentration: 3090 nM
For compound 4 the middle estimate is 1.1-fold (0.05 log units) above the measured one, and the stated range covers the measured number.
By their numbers in this assay, from the lowest: compounds 2, 3, 4 and 1 (each within the scatter of the next, the first and the last beyond it).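

The aryl group on an oxygen on a saturated carbon now shows that fluorine in the group does not alone place a compound: 3-(trifluoromethyl)phenyl cannot be separated from 2,4-dimethylphenyl (a 1.2-fold higher number from compound 3 to compound 4 (0.09 log units; within the scatter)) or from 4-fluorophenyl (a 1.7-fold lower number from compound 1 to compound 4 (0.24 log units; within the scatter)). Only 2,5-dimethylphenyl stands clear of it (a 2.0-fold higher number from compound 2 to compound 4 (0.31 log units; beyond the scatter)), and compound 3 goes against any split between fluorine-bearing and dimethyl aryl groups. No measurement at hand gives a reason for these steps. Open, going by these compounds, is whether an aryl group bearing an amine or a carboxylic acid would leave this narrow span. A longer chain in place of the saturated carbon also remains untested in the compounds shown.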